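Adding One Methyl to Compound 2

The source may report more compounds than this note shows. Statements on the series, on what has been measured and on what is new or still open speak of the compounds shown alone.

Compound 1 `COc1ccc(/C=C/C(=O)Nc2nnc(-c3ccc(C)cc3)s2)cc1` gives 0.35 ug/mL
Compound 2 `O=C(/C=C/c1ccccc1)Nc1nnc(-c2ccccc2)s1` gives 1.47 ug/mL

Both numbers come from a functional assay on MCF7 cells (Homo sapiens) for antiproliferative activity, read by MTT assay, with a stated time of 48 h (a lower number here means a stronger inhibitor, a higher number a weaker inhibitor), and, of the two, compound 2 has the higher at 1.47 ug/mL and so is the weaker inhibitor. Its gap to compound 1 lies beyond the usual scatter of repeated measurements.

The next compound to be tested is compound 3 `Cc1ccc(-c2nnc(NC(=O)/C=C/c3ccccc3)s2)cc1` which turns the phenyl of compound 2 into 4-methylphenyl (methyl in place of hydrogen on an aromatic carbon). This places methyl in place of hydrogen on an aromatic carbon, para to a large group.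

Among the compounds with values here, no measured pair here differs in one place only, so the effect of a single methyl in this assay has not been seen. The one guide is compound 1 at 0.35 ug/mL which shows that a number well under that of compound 2 can occur among these compounds. The estimate is a small drop a 1.6-fold lower number from compound 2 to compound 3 (0.21 log units; within the scatter) in the number, perhaps no larger than the scatter. For compound 3 the expected value is 0.9 ug/mL with 0.3 ug/mL to 2.7 ug/mL as the estimated range.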

Compound 3, half-maximal inhibitory concentration: 1.19 ug/mL
Estimate against measurement, compound 3: 1.3-fold (0.12 log units) below; the range from low to high includes it.
By their numbers in this assay, from the lowest: compound 1; then compounds 3 and 2 (each within the scatter of the next).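

In this assay, within the data shown here, this is the first direct look at a single methyl: turning phenyl into 4-methylphenyl gives a 1.2-fold lower number from compound 2 to compound 3 (0.09 log units; within the scatter) and so, at this position, para to a large group, methyl and hydrogen cannot be told apart. The second single-place comparison, at a different place in the molecule, gives a 3.4-fold higher number from compound 1 to compound 3 (0.53 log units; beyond the scatter) with hydrogen in place of methoxy on an aromatic carbon, a step that stands clear of the scatter while the methyl stays in both compounds. Within this pair, then, the methoxy place marks a real difference in the number, whereas the methyl place shows none, and no measurement at hand explains either result.

On these data alone, whether methoxy would give a step of similar size on compound 2, which carries hydrogen where compound 3 has its methyl, remains open. Also open, as far as these compounds go, is whether a group other than methyl at the para place, such as a chlorine atom, an amine, a carboxylic acid or a longer chain, would move the number beyond the scatter where methyl does not.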